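The source may hold more compounds than are shown below. What is called first, only, known or untested is meant among the compounds shown, and "the series" means these compounds.

Compound 1 `COc1cc(/C=C/C(=O)C2=C(/C=C/c3ccc(O)c(OC)c3)NC(=O)NC2c2ccc(C)cc2)ccc1O` gives 17.2% in a functional assay, with a stated time of 20 min, tested at 2 uM; a lower number here means a weaker effect, a higher number a stronger effect of the compound at the concentration tested. Compound 2 `COc1cc(/C=C/C(=O)C2=C(/C=C/c3ccc(O)c(OC)c3)NC(=O)NC2c2c(Cl)cccc2Cl)ccc1O` gives 11.2% in this assay and stands alongside compound 1, the step of a number 6 percentage points lower from compound 1 to compound 2 (within the scatter) lying within the scatter. Compound 3 `COc1cc(/C=C/C(=O)C2=C(/C=C/c3ccc(O)c(OC)c3)NC(=O)NC2c2cccc([N+](=O)[O-])c2)ccc1O` carries the change (3-nitrophenyl in place of 2,6-dichlorophenyl on a saturated ring carbon). For the measured compounds named here, the only step that bears on it is the earlier swap of the group on the same saturated ring carbon, which stayed within the scatter, so no step beyond the scatter is expected here either; the expected step is a number 1.8 percentage points higher from compound 2 to compound 3 (within the scatter). Compound 3 is therefore estimated to give 13% in this assay, within 4% to 25%.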

Compound 3, a percentage reported as activity, at one concentration (the size of the read-out at that concentration, not a potency): 17%
Compound 3: the middle estimate sits 4 percentage points below what was measured; low and high end bracket the measured number.
By their numbers in this assay, from the lowest: compounds 2, 3 and 1 (each within the scatter of the next).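

With the 3-nitrophenyl group on the saturated ring carbon, the step of a number 5.8 percentage points higher from compound 2 to compound 3 (within the scatter) and the step of a number 0.2 percentage points lower from compound 1 to compound 3 (within the scatter) both lie within the scatter in this assay. Compounds 1, 2 and 3 therefore cannot be told apart, so this position now tolerates three differently substituted phenyl groups, including one bearing a nitro group, without a step beyond the scatter. Nothing available accounts for this result. As far as these compounds go, whether a phenyl ring bearing an amine or a carboxylic acid, or a cyclohexyl group or a longer chain in place of the phenyl ring, would give a step beyond the scatter remains open.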